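The source may report more compounds than this note shows. Statements on the series, on what has been measured and on what is new or still open speak of the compounds shown alone.

Measured so far in a functional assay on DU-145 cells (Homo sapiens) for cytotoxicity; a lower number here means a stronger inhibitor of growth, a higher number a weaker inhibitor of growth:

Compound 1, `COc1ccc(C2=C(c3ccc(SC)cc3)CC3CCCN3C2=O)cc1C`, gives 900 nM.
Compound 2, `CSc1ccc(C2=C(c3ccc(C)c(C)c3)C(=O)N3CCCC3C2)cc1`, gives 500 nM.
Compound 3, `CSc1ccc(C2=C(c3ccc(O)cc3)C(=O)N3CCCC3C2)cc1`, reaches only a limit of the assay, > 100000 nM.

Compound 2 has the lowest of the two real numbers, yet the gap a 1.8-fold lower number from compound 1 to compound 2 (0.26 log units; within the scatter) lies within the scatter, so compound 1 and compound 2 cannot be put in order. The step of an at least 200-fold higher number from compound 2 to compound 3 (2.30 log units; beyond the scatter), like an at least 110-fold higher number from compound 1 to compound 3 (2.04 log units; beyond the scatter), is a large loss, and it ends at the limit of > 100000 nM in this assay, at which 1 of the 3 values shown sits.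

Compound 4, `CSc1ccc(C2=C(c3ccc(SC)cc3)C(=O)N3CCCC3C2)cc1`, is the unmeasured compound. The change from compound 2 is 4-(methylsulfanyl)phenyl in place of 3,4-dimethylphenyl on a double-bonded ring carbon.

Going by the values given here, two measured steps bear on this. The swap of a methyl for a methoxy, a 1.8-fold lower number from compound 1 to compound 2 (0.26 log units; within the scatter), stayed within the scatter, showing that exchanging one small uncharged group for another at this position has so far changed little. The swap to a 4-hydroxyphenyl, an at least 200-fold higher number from compound 2 to compound 3 (2.30 log units; beyond the scatter), was a large loss, but compound 4 carries no hydroxyl and no hydrogen-bond donor. The step of a 1.2-fold higher number from compound 2 to compound 4 (0.08 log units; within the scatter) is therefore expected to fall within the scatter, with no clear direction. Compound 4 is estimated to give 600 nM, most likely between 200 nM and 2500 nM.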

Compound 4, concentration for 50% growth inhibition: 8000 nM
Estimate against measurement, compound 4: 13-fold (1.12 log units) below; measured number above the stated range.
By their numbers in this assay, from the lowest: compounds 2 and 1 (each within the scatter of the next); then compound 4. At a limit, above all of these: compound 3.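

In this assay, the step of a 16-fold higher number from compound 2 to compound 4 (1.20 log units; beyond the scatter) is large, even though 4-(methylsulfanyl)phenyl and 3,4-dimethylphenyl have the same count of heavy atoms and neither has a hydrogen-bond donor, so this position can separate two uncharged aromatic groups of matching size by atom count. The 4-methoxy-3-methylphenyl group also compares favourably with 4-(methylsulfanyl)phenyl, though by a modest step, an 8.9-fold higher number from compound 1 to compound 4 (0.95 log units; beyond the scatter), so the earlier impression that exchanges among small uncharged groups here change little holds for the pair compared before but not for this new group. The step of an at least 12-fold lower number from compound 3 to compound 4 (1.09 log units; beyond the scatter) places 4-(methylsulfanyl)phenyl between those groups and 4-hydroxyphenyl, and the value of compound 3 is a limit, not a number: the limit of > 100000 nM in this assay, at which 1 of the 4 values shown sits.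

The compounds shown do not separate the effect of the sulfur-containing group from that of losing the methyl group on the ring, since 4-(methylsulfanyl)phenyl differs from 3,4-dimethylphenyl in both respects. A 3-methyl-4-(methylsulfanyl)phenyl or a 4-methylphenyl group at this position would pull those two apart, and a 4-chlorophenyl or 4-aminophenyl group would show how far the range of this position extends.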